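A Bromophenyl Ring Replaces a Hydroxyethyl Chain

The source may hold more compounds than are shown below. What is called first, only, known or untested is meant among the compounds shown, and "the series" means these compounds.

Of the compounds shown here, three sharing one core have been measured in a functional assay on HCT-116 cells (Homo sapiens) for antiproliferative activity, read by MTT assay, with a stated time of 72 h; on this read-out lower numbers stand for stronger inhibition and higher numbers for weaker inhibition. Compound 1 `O=C1O[C@H]([C@@H](O)Cn2cc(-c3cccc(O)c3)nn2)C(OCc2ccccc2)=C1OCc1ccccc1` gives 42900 nM, compound 2 `O=C1O[C@H]([C@@H](O)Cn2cc(CNS(=O)(=O)c3ccc(Cl)cc3F)nn2)C(OCc2ccccc2)=C1OCc1ccccc1` gives 21600 nM, and compound 3 `O=C1O[C@H]([C@@H](O)Cn2cc(CCO)nn2)C(OCc2ccccc2)=C1OCc1ccccc1` gives 72700 nM, the highest number shown, although its gap to compound 1 lies within the scatter. The steps into compound 3 were a 1.7-fold higher number from compound 1 to compound 3 (0.23 log units; within the scatter) and a 3.4-fold higher number from compound 2 to compound 3 (0.53 log units; beyond the scatter). Compound 4 `O=C1O[C@H]([C@@H](O)Cn2cc(-c3ccc(Br)cc3)nn2)C(OCc2ccccc2)=C1OCc1ccccc1` differs from compound 3 at one place: 4-bromophenyl in place of 2-hydroxyethyl on an aromatic carbon. Going by the values given here, the only step that bears on this change is a 1.7-fold higher number from compound 1 to compound 3 (0.23 log units; within the scatter), in which a hydroxyphenyl group was traded for the hydroxyethyl chain; read backwards, an aromatic ring in place of the chain gave a difference that stayed within the scatter. For compound 4 a step of about a 1.9-fold lower number from compound 3 to compound 4 (0.28 log units; within the scatter) is therefore expected, not beyond the scatter. Compound 4 is estimated at 38000 nM, with a range from 15000 nM to 90000 nM.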

Compound 4, half-maximal inhibitory concentration: 9420 nM
Compound 4: middle estimate off by 4.0-fold (0.61 log units), on the high side; measured number outside the range, below it.
By their numbers in this assay, from the lowest: compound 4; then compounds 2, 1 and 3 (each within the scatter of the next, the first and the last beyond it).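

This position can carry a change beyond the scatter: in this assay, 4-bromophenyl in place of 2-hydroxyethyl gives a 7.7-fold lower number from compound 3 to compound 4 (0.89 log units; beyond the scatter), whereas the earlier exchange of a ring for the chain stayed within the scatter. The kind of ring also matters, as 4-bromophenyl in place of 3-hydroxyphenyl gives a 4.6-fold lower number from compound 1 to compound 4 (0.66 log units; beyond the scatter). No available evidence explains either step.

Still open, going by these compounds, is how a plain phenyl ring or a 3-bromophenyl ring would compare with compound 4. That comparison would separate the effect of the bromine from that of its place on the ring.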